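A Fluoro Shift on the Phenyl Ring of Compound 1

The compounds below may be only part of what the source reports. "The series", "measured", "known", "first", "only" and "open" are said of these compounds alone.

Compound 1 `O=C(O)C1CCN(c2ccccc2)C1` was tested in an assay on cells for inhibition of Palmitoleoyl-protein carboxylesterase NOTUM variant C330S (Homo sapiens), read by fluorescence, with a stated time of 40 min (on this read-out lower numbers stand for stronger inhibition and higher numbers for weaker inhibition), and gave 48000 nM, the second highest of the three numbers recorded. Its nearest neighbour is compound 3 `CC(C)c1cccc(N2CCC(C(=O)O)C2)c1`, which gives 57000 nM in this assay; the change from compound 1 to compound 3, an isopropyl in place of hydrogen on an aromatic carbon, amounts to a 1.2-fold higher number from compound 1 to compound 3 (0.07 log units; within the scatter). The furthest is compound 2 `O=C(O)C1CCN(c2ccccc2F)C1`, which gives 11000 nM; here a fluoro in place of hydrogen on an aromatic carbon produces a 4.4-fold lower number from compound 1 to compound 2 (0.64 log units; beyond the scatter).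

Compound 4 `O=C(O)C1CCN(c2ccc(F)cc2)C1` is not yet measured. It differs from compound 1 by fluoro in place of hydrogen on an aromatic carbon, the fluoro sitting on an aromatic carbon of a six-membered aromatic ring of carbon only, para to a group of 8 heavy atoms. Among the measured compounds shown here, two measured steps bear on it: the same fluoro group at a different place on the ring gave the modest improvement seen from compound 1 to compound 2, whereas a larger group elsewhere on the ring left the number within the scatter from compound 1 to compound 3. For the measured compounds named here, the data give no step for a fluoro at this exact position, so the expectation is a small change at most. Compound 4 is therefore expected to give about 30000 nM, with a range from 10000 nM to 90000 nM, and the step from compound 1 to compound 4 is estimated as a 1.6-fold lower number from compound 1 to compound 4 (0.20 log units; within the scatter).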

Compound 4, half-maximal inhibitory concentration: 15000 nM
Compound 4: the middle estimate sits 2.0-fold (0.30 log units) above what was measured; low and high end bracket the measured number.
By their numbers in this assay, from the lowest: compounds 2 and 4 (each within the scatter of the next); then compounds 1 and 3 (each within the scatter of the next).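

Placing a fluoro in place of hydrogen on an aromatic carbon, para to a group of 8 heavy atoms, is enough to move the number in this assay, with a 3.2-fold lower number from compound 1 to compound 4 (0.51 log units; beyond the scatter). Among the compounds shown here, the earlier compounds showed a step of this kind for a fluoro at only one place on the ring, but this result shows that the gain over the unsubstituted compound 1 is not confined to that place: compound 2 gives 11000 nM and compound 4 gives 15000 nM, two values within the usual scatter of each other, so these data do not separate the two fluoro positions. Nothing available explains why the fluoro has this effect at either place.

The compounds shown leave open whether the effect at this position is particular to fluoro or would also appear with a chlorine, a methoxy group or an isopropyl group there. They also leave open whether fluoro groups at both places would add together on the shared core, and whether any of these steps would hold if an amide replaced the carboxylic acid.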